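Benzyl ester series: trifluoromethyl in place of fluoro

The source may hold more compounds than are shown below. What is called first, only, known or untested is meant among the compounds shown, and "the series" means these compounds.

Compound 3 `O=C(OCc1ccc(F)cc1)c1cccc(=O)[nH]1` gives 3000 nM in an assay on isolated protein for inhibition of matrix metalloproteinase-9 (Homo sapiens) (on this read-out higher numbers stand for weaker inhibition and lower numbers for stronger inhibition), and stands lowest of the three numbers, with every other compound beyond the scatter from it. Compound 1 `O=C(OCc1ccccc1)c1cccc(=O)[nH]1` gives 69000 nM, and compound 2 `COc1ccc(COC(=O)c2cccc(=O)[nH]2)cc1` gives 100000 nM; the step of a 1.4-fold higher number from compound 1 to compound 2 (0.16 log units; within the scatter) lies within the scatter. The steps bearing on the next change are a 23-fold lower number from compound 1 to compound 3 (1.36 log units; beyond the scatter) and a 33-fold lower number from compound 2 to compound 3 (1.52 log units; beyond the scatter), both large, both ending at the fluoro compound. Compound 4 `O=C(OCc1ccc(C(F)(F)F)cc1)c1cccc(=O)[nH]1` differs from compound 3 by trifluoromethyl in place of fluoro on an aromatic carbon. Among the measured compounds shown here, no measured step covers trifluoromethyl; compound 1 and compound 2 show that the other two groups tried at this carbon sit far above compound 3, so a higher number than compound 3 is expected, of uncertain size. For compound 4 the expected step is a 5.0-fold higher number from compound 3 to compound 4 (0.70 log units; beyond the scatter). Compound 4 is estimated at 15000 nM, within 3000 nM to 80000 nM.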

Compound 4, half-maximal inhibitory concentration: 101000 nM
Compound 4: middle estimate off by 6.7-fold (0.83 log units), on the low side; the measured number lies above the stated range.
By their numbers in this assay, from the lowest: compound 3; then compounds 1, 2 and 4 (each within the scatter of the next).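

In this assay the move to trifluoromethyl gives a 34-fold higher number from compound 3 to compound 4 (1.53 log units; beyond the scatter) and so loses the whole gain seen with fluoro at this carbon. Trifluoromethyl does no better than hydrogen, with a 1.5-fold higher number from compound 1 to compound 4 (0.17 log units; within the scatter) and no better than methoxy, with a 1.0-fold higher number from compound 2 to compound 4 (0.00 log units; within the scatter) and this leaves compound 3 alone among the four and shows that carrying fluorine is not enough. Nothing at hand accounts for this result. Going by these compounds, whether chloro or a nitrile on this carbon would stand with compound 3 or with the other three remains open. So does whether the gain of compound 3 survives an amide in place of the ester.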